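The source may report more compounds than this note shows. Statements on the series, on what has been measured and on what is new or still open speak of the compounds shown alone.

Measured compounds in a functional assay on HL-60 cells (Homo sapiens) for inhibition, read by MTT assay; on this read-out higher numbers stand for weaker inhibition and lower numbers for stronger inhibition:
compound 1 `Nc1nc(-c2ccccc2)cc(-c2cnn(-c3ccccc3)n2)n1`, compound 1 gives 66500 nM
compound 2 `Nc1ccc(-c2cc(-c3cnn(-c4ccccc4)n3)nc(N)n2)cc1`, compound 2 gives 68200 nM
compound 3 `Nc1nc(-c2ccccc2)cc(-c2cccs2)n1`, compound 3 gives 70300 nM

Compound 3 holds the highest of the three numbers, but its gaps to compound 2 and to compound 1 are both within the scatter, so no order among the three can be read. For the measured compounds named here, the single measured step, a 1.0-fold higher number from compound 1 to compound 2 (0.01 log units; within the scatter), is likewise within the scatter. Compound 4 `Nc1nc(-c2ccccc2)cc(-c2ccc[nH]2)n1` is the untested member; it differs from compound 3 by 1H-pyrrol-2-yl in place of thiophen-2-yl on an aromatic carbon. Going by the values given here, no measured step touches this position of the shared core, and the one step available is flat, so the change from compound 3 to compound 4 is expected to stay within the scatter in this assay, with no direction preferred. Compound 4 is therefore estimated at 70000 nM, range 25000 nM to 200000 nM, which means an expected step of a 1.0-fold lower number from compound 3 to compound 4 (0.00 log units; within the scatter).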

Compound 4, half-maximal inhibitory concentration: 29300 nM
Compound 4: middle estimate off by 2.4-fold (0.38 log units), on the high side, within the range that was stated.
By their numbers in this assay, from the lowest: compound 4; then compounds 1, 2 and 3 (each within the scatter of the next).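

Replacing thiophen-2-yl with 1H-pyrrol-2-yl gives a 2.4-fold lower number from compound 3 to compound 4 (0.38 log units; beyond the scatter) in this assay, the only step shown that lies beyond the scatter, so this position of the shared core does respond to a change of five-membered ring. The two rings match in heavy-atom count and differ in the hetero atom and in their hydrogen-bond donor and acceptor counts. Nothing measured here accounts for the step. On these data alone, whether the gain depends on the ring nitrogen's hydrogen remains open, and furan-2-yl or 1-methylpyrrol-2-yl at this position would address that. Also open, as far as these compounds go, is whether the step persists with an amino group on the phenyl ring.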